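A few compounds are considered here, and "the series" means these few. Any claim that something is new, unique, unknown or untested is made for them only; others in the source may bear on it.

Compound 1 `O=C1C(NC2CCCC2)=CC(=O)c2c1nc1n2[C@H]2OC[C@@H](O)[C@H]2OC1` — > 16000 nM
Compound 2 `CCOc1ccccc1NC1=CC(=O)c2nc3n(c2C1=O)[C@H]1OC[C@@H](O)[C@H]1OC3` — 4630 nM
Compound 3 `Cc1ccc(NC2=CC(=O)c3nc4n(c3C2=O)[C@H]2OC[C@@H](O)[C@H]2OC4)cc1C` — 2820 nM

In a functional assay on ECa-109 cells for inhibition, with ECa-109 cell line (Homo sapiens) as the target, read by sulforhodamine B assay (on this read-out lower numbers stand for stronger inhibition and higher numbers for weaker inhibition), compound 1 gives only a limit of the assay, > 16000 nM. Compound 2 gives 4630 nM and compound 3 gives 2820 nM; the step of a 1.6-fold lower number from compound 2 to compound 3 (0.22 log units; within the scatter) lies within the scatter, so these two stand level. Compound 4 `O=C1C(NCc2ccccc2)=CC(=O)c2c1nc1n2[C@H]2OC[C@@H](O)[C@H]2OC1` differs from compound 1 by benzyl in place of cyclopentyl on an amine nitrogen. Going by the values given here, no measured step covers this exchange: the only one swaps one aromatic group for another. What is seen is that compound 1 sits at the limit (the limit of > 16000 nM in this assay, at which 1 of the 3 values shown sits), whereas compound 2 and compound 3, each bearing an aromatic ring on the amine nitrogen, give measurable numbers. Compound 4 is therefore expected to give about 8000 nM, within 2500 nM to 30000 nM, which would mean an at least 2.0-fold lower number from compound 1 to compound 4 (0.30 log units; that floor lies within the scatter), though a limit remains quite possible.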

Compound 4, half-maximal inhibitory concentration: > 8000 nM
Compound 4: a limit, no number; the forecaster's own chance of this, stated with the estimate: 40%; the middle value lies on the limit itself.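

Compound 1 gives only a limit, > 16000 nM. Compound 4 also gives only a limit, > 8000 nM. Going by these compounds alone, no step between these two compounds can be read. From the compounds shown here alone, whether benzyl in place of cyclopentyl changes inhibition at all stays open.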